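The source may hold more compounds than are shown below. What is called first, only, known or untested is meant among the compounds shown, and "the series" means these compounds.

Measured compounds:
compound 1 `O=C(Nc1cccc(S(=O)(=O)N2CCCC2)c1)c1cccnc1N1CCC2(CC1)CC2` — > 399 mL.min-1.g-1
compound 2 `CC(C)(C)NS(=O)(=O)c1cccc(NC(=O)c2ccc(NC(C)(C)CO)nc2N2CCC3(CC2)CC3)n1` — > 399 mL.min-1.g-1
compound 3 `CC(C)(CO)Nc1ccc(C(=O)Nc2cccc(S(=O)(=O)NC3CCCC3)n2)c(N2CCC3(CC2)CC3)c1` — > 399 mL.min-1.g-1

In an ADME assay on microsomes from liver (Homo sapiens) for metabolic stability, read by LC-MS, with a stated time of 40 min, tested at 0.5 uM (a higher number here means faster removal of the compound, a lower number slower removal), compound 1 gives > 399 mL.min-1.g-1, which is a limit of the assay rather than a number. Compound 2 likewise gives only a limit, > 399 mL.min-1.g-1, in this assay. Compound 3 gives the same limit, > 399 mL.min-1.g-1. So compound 1 stands nowhere distinct on the numbers shown: the limit of > 399 mL.min-1.g-1 in this assay, at which 3 of the 3 values shown sit, and no step between any two of these compounds can be sized from them.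

The next compound is compound 4 `O=C(Nc1cccc(S(=O)(=O)C2CCCC2)c1)c1cccnc1N1CCC2(CC1)CC2`. It differs from compound 1 in one place, (cyclopentyl in place of pyrrolidin-1-yl on a sulfonyl sulfur). Among the measured compounds shown here, with all three measured values sitting at the limit, there is no measured step to set the direction or size of this change, and the change itself carries no measured property here.

The expectation is that compound 4 stays at or near the limit, so the step that the limit leaves unreadable from compound 1 to compound 4 is expected to be none beyond the scatter. The estimate for compound 4 in this assay is 450 mL.min-1.g-1, within 200 mL.min-1.g-1 to 1000 mL.min-1.g-1, and it is expected that this assay again reports only a limit for compound 4.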

Compound 4, intrinsic clearance in microsomes: > 399 mL.min-1.g-1
Compound 4 ended at the assay's limit; the forecaster's own chance of this, stated with the estimate: 70%; the middle value lies beyond the limit too.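

Compound 1 and compound 4 each give only a limit in this assay, not a number, so the step between them cannot be read: the limit of > 399 mL.min-1.g-1 in this assay, at which 4 of the 4 values shown sit.

The compounds shown leave open how fast each is removed, and whether cyclopentyl in place of pyrrolidin-1-yl on a sulfonyl sulfur alters that removal at all.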